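This account rests on a few compounds, and the source may have more. Where it says the series, first, only, none or still open, it means among the compounds named here.

Measured compounds:

Compound 1 `Oc1ccccc1-c1c[nH]nn1`: 14%
Compound 2 `Clc1cccc(-c2c[nH]nn2)c1/C=C/c1ccccc1`: 97%

Both compounds were tested in an assay on cells for inhibition of Indoleamine 2,3-dioxygenase 2 (Mus musculus), with a stated time of 24 h, tested at 200 uM; a lower number here means less inhibition, a higher number more inhibition at the concentration tested (going by the name of the read-out). Of the two numbers, compound 2 stands highest, giving 97%, while compound 1 gives 14%, a gap wide enough to sit beyond the usual scatter of repeated measurements. Within the data shown here, no pair of compounds that differ in a single place has been measured, so there is no measured step to lean on.

Compound 3 `Clc1cccc(-c2c[nH]nn2)c1/C=C/C1CCCCC1` has not yet been measured. It differs from compound 2 in one place: cyclohexyl in place of phenyl on a double-bonded chain carbon bound to a double-bonded chain carbon. The change swaps one six-membered ring of carbon for another of the same size, keeping the rest of compound 2 untouched.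

Among the measured compounds shown here, with no measured step of this kind, the expectation rests only on compound 2 and its value of 97%. A modest fall is expected, of the size a number 22 percentage points lower from compound 2 to compound 3 (beyond the scatter), though a result within the scatter of compound 2 would not surprise. Compound 3 is therefore estimated at 75% in this assay, within a range from 40% to 97%.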

Compound 3, a percentage reported as inhibition, at one concentration (the size of the read-out at that concentration, not a potency): 65%
Estimate against measurement, compound 3: 10 percentage points above, within the range that was stated.
By their numbers in this assay, from the lowest: compound 1; then compound 3; then compound 2.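

Replacing the aromatic phenyl with the non-aromatic cyclohexyl, on a double-bonded chain carbon bound to a double-bonded chain carbon, brings a number 32 percentage points lower from compound 2 to compound 3 (beyond the scatter) in this assay, so this place responds to the kind of ring even when the ring size and the count of carbons stay the same. Compound 3 still gives 65%, which shows that an aromatic ring at this place is not an absolute need for a sizeable reading at the concentration tested. No measurement at hand explains the difference between the two rings.

The compounds shown leave open how other groups would read at this same place, such as a smaller cyclopentyl ring, a longer open carbon chain, or a pyridyl ring, which carries a nitrogen atom within the ring. Going by these compounds, it also stays open how large the difference between phenyl and cyclohexyl would be at other concentrations, as a percentage taken at a single concentration is a size of effect and not a potency.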